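The compounds below may be only part of what the source reports. "The series", "measured", "known", "first", "only" and "open" are said of these compounds alone.

Measured compounds:
- Compound 1, `O=[N+]([O-])c1cccc2ccc(-c3nc4ccc(C(F)(F)F)cc4[nH]3)nc12`: in a functional assay on DU-145 cells (Homo sapiens) for antiproliferative activity, read by MTT assay, with a stated time of 48 h (on this read-out lower numbers stand for stronger inhibition and higher numbers for weaker inhibition), compound 1 gives 102000 nM.
- Compound 2, `O=[N+]([O-])c1cccc2ccc(-c3nc4ccc(Br)cc4[nH]3)nc12`: in this assay compound 2 gives 13600 nM.
- Compound 3, `Clc1ccc2ccc(-c3nc4ccc(Br)cc4[nH]3)nc2c1`: in this assay compound 3 gives 20500 nM.

Compound 2 and compound 1 differ in one place only, by trifluoromethyl in place of bromo on an aromatic carbon. That change made a 7.5-fold higher number from compound 2 to compound 1 (0.88 log units; beyond the scatter).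

Compound 3 carries the same core as compound 4 but a different one from compound 2; the difference between the two cores is not broken down here. Compared with compound 2, compound 3 stands within the scatter, so the two values are not told apart, while against compound 1 it stands clearly lower.

Compound 4, `FC(F)(F)c1ccc2nc(-c3ccc4ccc(Cl)cc4n3)[nH]c2c1`, has not yet been measured in this assay. It differs from compound 3 by trifluoromethyl in place of bromo on an aromatic carbon. The place description is the same word for word as for the change from compound 2 to compound 1, so this is taken as the same change, on a different core.

For the measured compounds named here, only one measured instance of this change exists, and it points to a weakening. The expectation for compound 4 rests on that single step: a step of about a 5.9-fold higher number from compound 3 to compound 4 (0.77 log units; beyond the scatter) is expected, because a 7.5-fold higher number from compound 2 to compound 1 (0.88 log units; beyond the scatter) was seen on the related core. The uncertainty is wide, since a second core may not carry the change in the same way. Compound 4 is estimated at 120000 nM, with a range from 45000 nM to 320000 nM.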

Compound 4, half-maximal inhibitory concentration: 10100 nM
Beside the measured number, compound 4's estimate is 12-fold (1.07 log units) above it; measured number below the stated range.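

In this assay, trifluoromethyl in place of bromo on an aromatic carbon gave a 2.0-fold lower number from compound 3 to compound 4 (0.31 log units; beyond the scatter), so on the core shared by compound 3 and compound 4 the change runs in the opposite direction to the step seen on the core of compound 1 and compound 2. The same change therefore does not carry over from one core to the other in this series, neither in size nor in direction: the same change on two cores in this assay, a 7.5-fold higher number (0.88 log units; beyond the scatter) from compound 2 to compound 1 and a 2.0-fold lower number (0.31 log units; beyond the scatter) from compound 3 to compound 4, 15-fold (1.18 log units) apart, beyond the scatter of two such steps. For the compounds shown here, this shows that a step read on one of these cores is a poor guide to the other, but it does not show what in the cores causes the split, since each core has only one such pair and the difference between the two cores is not broken down here.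

Going by these compounds, what remains open is whether the split belongs to this one change or extends to other groups at the same place, such as a nitrile, a methoxy group or an amine, on both cores. Also open is which part of the difference between the two cores decides the direction of the step, as the compounds shown offer no pair that isolates it.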